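The source may hold more compounds than are shown below. What is called first, only, known or untested is meant among the compounds shown, and "the series" means these compounds.

Compound 1 `O=C1c2ccccc2C(=O)N1CCOC(=S)N(C(=O)c1ccc(F)c(F)c1)c1ccc(Cl)cc1`: 52000 nM
Compound 2 `COc1cccc(OC)c1C(=O)N(C(=S)OCCN1C(=O)c2ccccc2C1=O)c1ccc(Cl)cc1`: 69000 nM

These two values come from an ADME assay on MT4 cells (Homo sapiens) for cytotoxicity, read by MTT assay; a higher number here means that more compound is tolerated, a lower number that less compound is tolerated. For the measured compounds named here, compound 2 stands level with the only other measured compound, since the single measured step, a 1.3-fold higher number from compound 1 to compound 2 (0.12 log units; within the scatter), lies within the usual scatter. That step exchanges one substituted phenyl group for another on the same carbonyl carbon.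

Compound 3 `O=C1c2ccccc2C(=O)N1CCOC(=S)N(C(=O)c1cc([N+](=O)[O-])ccc1Cl)c1ccc(Cl)cc1` has not yet been measured, and its change falls at that same place: 2-chloro-5-nitrophenyl in place of 2,6-dimethoxyphenyl on a carbonyl carbon. In other words, 2-chloro-5-nitrophenyl takes the place of 2,6-dimethoxyphenyl on a carbonyl carbon. Neither measured compound carries this new group, and one step is thin evidence, so the range has to stay wide. Even so, the exchange at this place gave only a 1.3-fold higher number from compound 1 to compound 2 (0.12 log units; within the scatter), so no step beyond the scatter is expected in this assay, in either direction. The estimate amounts to an expected 1.3-fold lower number from compound 2 to compound 3 (0.10 log units; within the scatter). Compound 3 is expected at 55000 nM, with an estimated range of 20000 nM to 120000 nM.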

Compound 3, half-maximal cytotoxic concentration: 45000 nM
Compound 3: the middle estimate sits 1.2-fold (0.09 log units) above what was measured; the range from low to high includes it.
By their numbers in this assay, from the lowest: compounds 3, 1 and 2 (each within the scatter of the next).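

In this assay, swapping the group on this carbonyl carbon once more leaves the number level: 2-chloro-5-nitrophenyl in place of 2,6-dimethoxyphenyl gives (a 1.5-fold lower number from compound 2 to compound 3 (0.19 log units; within the scatter)), and 2-chloro-5-nitrophenyl in place of 3,4-difluorophenyl gives (a 1.2-fold lower number from compound 1 to compound 3 (0.06 log units; within the scatter)). The earlier compounds offered a single exchange at this place, whereas three different substituted phenyl groups, carrying fluorine, methoxy, or chlorine with nitro, now all stand within the scatter of one another, so among these three compounds the choice of ring substituents makes no readable difference. Nothing measured here offers an explanation for this flat result.

On these data alone, all three compounds keep a substituted phenyl ring on this carbonyl carbon, so it remains open whether a group of another kind there, such as a plain methyl, a longer alkyl chain, an amine or a carboxylic acid, would stay level too. The rest of the shared core is also the same throughout, so these compounds say nothing about how the number responds to a change anywhere else in the molecule.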